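This account rests on a few compounds, and the source may have more. Where it says the series, first, only, none or still open, it means among the compounds named here.

Among the measured compounds shown here, in an assay on isolated protein for agonist activity at Bile acid receptor (Homo sapiens), read by FRET (on this read-out lower numbers stand for an effect already at smaller amounts and higher numbers for an effect only at larger amounts of compound), compound 1 `CC(C)c1onc(-c2c(Cl)cccc2Cl)c1COc1ccc(N(C)C(=O)c2ccc(C(=O)O)cc2)c(C(F)(F)F)n1` gives 235 nM, the second highest of the three numbers known so far. For the measured compounds named here, compound 3 `Cc1cc(C(F)(F)F)cc(OCc2c(-c3c(Cl)cccc3Cl)noc2C(C)C)n1` gives 225 nM, and compound 2 `Cc1nc(OCc2c(-c3c(Cl)cccc3Cl)noc2C(C)C)ccc1N(C)C(=O)c1ccc(C(=O)O)cc1` gives 365 nM; the only single-point step among them, a 1.6-fold higher number from compound 1 to compound 2 (0.19 log units; within the scatter), lies within the scatter. Compound 4 `CC(C)c1onc(-c2c(Cl)cccc2Cl)c1COc1ccc(N(C)Cc2cccc(C(=O)O)c2)c(C(F)(F)F)n1` differs from compound 1 in one place: 3-carboxybenzyl in place of (4-carboxyphenyl)carbonyl on a nitrogen on an aromatic ring. Going by the values given here, no measured step touches this part of the shared core, so nothing measured bears directly on the change, and the swap of (4-carboxyphenyl)carbonyl for 3-carboxybenzyl is a larger alteration than the one seen in this assay from compound 1 to compound 2. Compound 4 is therefore expected to show a higher number, a 3.0-fold higher number from compound 1 to compound 4 (0.47 log units; beyond the scatter). Compound 4 is estimated at 700 nM, with a range from 200 nM to 3000 nM.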

Compound 4, half-maximal effective concentration: 12 nM
Compound 4: middle estimate off by 58-fold (1.77 log units), on the high side; measured number outside the range, below it.
By their numbers in this assay, from the lowest: compound 4; then compounds 3, 1 and 2 (each within the scatter of the next).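

Among the compounds shown here, the group on this nitrogen turns out to have a large effect in this assay, which the earlier compounds could not show: replacing (4-carboxyphenyl)carbonyl with 3-carboxybenzyl gives a 20-fold lower number from compound 1 to compound 4 (1.29 log units; beyond the scatter). This one change removes the carbonyl and also moves the carboxylic acid to a different numbered place on the ring, so the two alterations cannot be separated here. Nothing available explains the step.

The compounds shown leave open whether 4-carboxybenzyl or (3-carboxyphenyl)carbonyl would give a number closer to that of compound 4 or compound 1.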